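A few compounds are considered here, and "the series" means these few. Any claim that something is new, unique, unknown or untested is made for them only; others in the source may bear on it.

Three measured compounds share one core and differ only at the aryl amide end. Compound 1 `Cc1ccc(C(=O)NCN2CCC(c3cccc[n+]3[O-])CC2)cc1C` gives 65% in a functional assay on HEK293 cells for agonist activity at D(4) dopamine receptor (Homo sapiens), read by FLIPR; on this read-out higher numbers stand for larger maximal responses and lower numbers for smaller maximal responses. Compound 2 `Cc1cc(C)cc(NC(=O)CN2CCC(c3cccc[n+]3[O-])CC2)c1` gives 76% in this assay, and compound 3 `CSc1cccc(NC(=O)CN2CCC(c3cccc[n+]3[O-])CC2)c1` gives 56%. On these numbers compound 1 stands second highest of the three: compound 2 lies above it beyond the scatter, while compound 3 sits within the scatter of compound 1, so no order between those two can be claimed.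

Compound 4 `N#Cc1cccc(C(=O)NCN2CCC(c3cccc[n+]3[O-])CC2)c1` has not been measured. It differs from compound 1 by 3-cyanophenyl in place of 3,4-dimethylphenyl on a carbonyl carbon. Among the compounds with values here, the one measured step that resembles this change is a number 20 percentage points lower from compound 2 to compound 3 (beyond the scatter), where a dimethylphenyl group likewise gave way to a differently substituted phenyl, although there the exchange sat on the amide-type nitrogen rather than on the carbonyl carbon. That single comparison points toward a modest fall in maximal response, with considerable uncertainty because it rests on one pair. The expected step is therefore a number 11 percentage points lower from compound 1 to compound 4 (beyond the scatter). Compound 4 is thus expected to reach 54%, within a range from 38% to 70%.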

Compound 4, largest response reached (reported as efficacy), in percent of the reference or control that the assay uses: 69%
Beside the measured number, compound 4's estimate is 15 percentage points below it; the measured number falls inside the stated range.
By their numbers in this assay, from the lowest: compounds 3, 1, 4 and 2 (each within the scatter of the next, the first and the last beyond it).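

On a carbonyl carbon, 3-cyanophenyl in place of 3,4-dimethylphenyl gives a number 4 percentage points higher from compound 1 to compound 4 (within the scatter) in this assay, so this exchange brings no difference that can be told apart from the scatter. The earlier step on an amide-type nitrogen, a number 20 percentage points lower from compound 2 to compound 3 (beyond the scatter), therefore gives no general rule for replacing a dimethylphenyl group: here, a phenyl ring carrying a nitrile serves as well as the dimethylphenyl group on this read-out. No measurement shown here explains why the two steps differ.

A single step cannot separate the loss of the methyl groups from the arrival of the nitrile, and a plain phenyl group on the same carbonyl carbon would help to tell them apart. On these data alone, how a carboxylic acid or an amine on this ring would fare also remains open.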